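Adenosine-like compounds in a breast cancer cell growth assay

A few compounds are considered here, and "the series" means these few. Any claim that something is new, unique, unknown or untested is made for them only; others in the source may bear on it.

For the measured compounds named here, compound 2 `Cc1ccc(O)c(CNc2ncnc3c2ncn3[C@@H]2O[C@H](CO)[C@@H](O)[C@H]2O)c1` is one of two compounds measured in a functional assay on MCF cells (Homo sapiens) for antiproliferative activity, with a stated time of 72 h; a higher number here means a weaker inhibitor, a lower number a stronger inhibitor. In this assay compound 2 gives only a limit, > 166000 nM, not a number. Compound 1 `OC[C@H]1O[C@@H](n2cnc3c(NCc4c(F)ccc(F)c4F)ncnc32)[C@H](O)[C@@H]1O` is its closest neighbour. In this assay compound 1 likewise gives only a limit, > 166000 nM. Going by the values given here, the one step between them, a step that the two limits leave unreadable from compound 1 to compound 2, therefore cannot be read, because the limit of > 166000 nM in this assay, at which 2 of the 2 values shown sit, both values sit at the same edge of what the assay reports. Compound 3 `OC[C@H]1O[C@@H](n2cnc3c(NCc4ccc(C(F)(F)F)cc4)ncnc32)[C@H](O)[C@@H]1O` differs from compound 2 in one place: 4-(trifluoromethyl)phenyl in place of 2-hydroxy-5-methylphenyl on a saturated chain carbon bound to a nitrogen on an aromatic ring. Among the compounds with values here, no measured step speaks to this change, and both neighbours show no measurable inhibition of cell growth. The step from compound 2 to compound 3 is expected to stay within the scatter, a step that the limit leaves unreadable from compound 2 to compound 3. Compound 3 is therefore estimated to give about 200000 nM in this assay, somewhere between 50000 nM and 600000 nM, most likely reported again only as a limit.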

Compound 3, half-maximal inhibitory concentration: > 166000 nM
Compound 3: a limit, no number (the forecaster's own chance of this, stated with the estimate: 80%); the middle value is on the limit's open side.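

The steps from compound 1 and compound 2 to compound 3 cannot be read, because all three compounds stop at the same reported limit: the limit of > 166000 nM in this assay, at which 3 of the 3 values shown sit.

As far as these compounds go, how far apart these three compounds truly lie, and whether any group in this place gives a readable number, stays open.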